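This account rests on a few compounds, and the source may have more. Where it says the series, first, only, none or still open, it means among the compounds named here.

Measured so far:

compound 1, `CC(=O)Nc1ccc(O)c(C(=O)/C=C/c2ccccc2)c1`: 85500 nM
compound 2, `COc1cccc(/C=C/C(=O)c2cc(NC(C)=O)ccc2O)c1`: 93700 nM
compound 3, `Nc1ccc2oc(-c3ccccc3)c(O)c(=O)c2c1`: 27000 nM

All three were tested in an ADME assay on THP-1 cells (Homo sapiens) for cytotoxicity, read by flow cytometry and propidium iodide staining, with a stated time of 72 h; on this read-out lower numbers stand for stronger inhibition and higher numbers for weaker inhibition. Compound 2 differs from compound 1 in one place, (methoxy in place of hydrogen on an aromatic carbon), and the step of a 1.1-fold higher number from compound 1 to compound 2 (0.04 log units; within the scatter). Compound 3 is built on a different core; the difference between the core of compound 1 and that of compound 3 is not broken down here. Compound 3 carries the lowest number of the three, and its gaps to compound 1 and to compound 2 both lie beyond the scatter, so it stands apart from the other two in this assay.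

Compound 4, `COc1ccccc1-c1oc2ccc(N)cc2c(=O)c1O`, has not yet been measured. It differs from compound 3 by methoxy in place of hydrogen on an aromatic carbon. This is the same kind of change as that from compound 1 to compound 2, though not the same: in compound 2 the group sits meta to a large group, in compound 4 ortho to a large group. Because the earlier step of a 1.1-fold higher number from compound 1 to compound 2 (0.04 log units; within the scatter) stayed within the scatter, a similarly small step is expected here, a 1.1-fold higher number from compound 3 to compound 4 (0.05 log units; within the scatter). Compound 4 is therefore estimated at 30000 nM, with a likely range from 12000 nM to 75000 nM.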

Compound 4, half-maximal inhibitory concentration: 102000 nM
The estimate for compound 4 lay 3.4-fold (0.53 log units) below the measured number; measured number outside the range, above it.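

In this assay, the methoxy change does not carry over evenly from one core to the other. On the core of compound 3 it gives a 3.8-fold higher number from compound 3 to compound 4 (0.58 log units; beyond the scatter), and set beside the earlier step, the result differs clearly: the same change on two cores in this assay, a 1.1-fold higher number (0.04 log units; within the scatter) from compound 1 to compound 2 and a 3.8-fold higher number (0.58 log units; beyond the scatter) from compound 3 to compound 4, 3.4-fold (0.54 log units) apart, beyond the scatter of two such steps This does not show what separates the two steps, however: the cores differ, the methoxy of compound 4 stands ortho to a large group while that of compound 2 does not, and two pairs cannot pull these apart.

The compounds shown leave open whether methoxy ortho to a large group on the core of compound 1 would give a step like the one on the core of compound 3. They also leave open whether an ethoxy group, a fluorine atom or a hydroxyl group in that same place on the core of compound 3 would move the number as methoxy does.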